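A Bromo Analogue Beside Three Compounds at the Limit

The compounds below may be only part of what the source reports. "The series", "measured", "known", "first", "only" and "open" are said of these compounds alone.

Compound 3 `Cc1cc(-c2nc(-c3ccc(CCC(=O)O)cc3C)no2)ccc1OC(C)C` was examined in a functional assay on CHO cells with sphingosine 1-phosphate receptor 2 (Homo sapiens) as the target, read by GTPgammaS binding; on this read-out higher numbers stand for an effect only at larger amounts of compound and lower numbers for an effect already at smaller amounts. In this assay compound 3 gives only a limit, > 10000 nM. Compound 1 `Cc1cc(CCC(=O)O)ccc1-c1noc(-c2ccc(OC(C)C)c(F)c2)n1` likewise reaches only a limit in this assay, > 10000 nM. Compound 2 `Cc1cc(CCC(=O)O)ccc1-c1noc(-c2ccc(OC(C)C)c(Cl)c2)n1` also yields only a limit, > 10000 nM. The steps a step that the two limits leave unreadable from compound 1 to compound 2, a step that the two limits leave unreadable from compound 1 to compound 3 and a step that the two limits leave unreadable from compound 2 to compound 3 cannot be sized because of the limit of > 10000 nM in this assay, at which 3 of the 3 values shown sit. Compound 4 `Cc1cc(CCC(=O)O)ccc1-c1noc(-c2ccc(OC(C)C)c(Br)c2)n1` differs from compound 3 by bromo in place of methyl on an aromatic carbon. Since the measured fluoro, chloro and methyl variants at this aromatic carbon all stayed at the limit, no step beyond the scatter is expected, and compound 4 is expected to remain at the limit too, with an estimated step that the limit leaves unreadable from compound 3 to compound 4. For compound 4 the estimate is 20000 nM, within a range from 7000 nM to 100000 nM.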

Compound 4, half-maximal effective concentration: > 10000 nM
Compound 4 was reported as a limit; the forecaster's own chance of this, stated with the estimate: 85%; the middle value lies beyond the limit too.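

Going by these compounds alone, compound 4 reaches only a limit, as do compound 1, compound 2 and compound 3, so no step among them can be read in this assay: the limit of > 10000 nM in this assay, at which 4 of the 4 values shown sit. The compounds shown leave open how far any of them lies beyond that limit.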